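Lengthening the Saturated Chain on an Epoxide Ester

The source may hold more compounds than are shown below. What is called first, only, known or untested is meant among the compounds shown, and "the series" means these compounds.

Compound 1 `CCCCC/C=C/CCCCCCCCCC1(C(=O)OC)CO1` gives 680 nM in an assay on isolated protein (Rattus norvegicus) for inhibition of carnitine palmitoyltransferase 1A (Sus scrofa); on this read-out higher numbers stand for weaker inhibition and lower numbers for stronger inhibition; compound 2 `CCCCCCCCCCCC1(C(=O)OC)CO1` gives 1160 nM in this assay.

Among the compounds with values here, only two compounds have been measured, and the one step between them, a 1.7-fold higher number from compound 1 to compound 2 (0.23 log units; within the scatter), lies within the scatter of repeated measurements. Compound 2 sits at one end of these two numbers, but the gap to compound 1 is too small to say that the two differ at all.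

Compound 3 `CCCCCCCCCCCCCCC1(C(=O)OC)CO1` is reached from compound 2 by a single change: propyl in place of hydrogen on a saturated chain carbon, ten or more bonds along the chain from a saturated ring carbon. Within the data shown here, the only measured step that bears on it is the one from compound 1 to compound 2, which also altered the length of the chain and stayed within the scatter. Because a 1.7-fold higher number from compound 1 to compound 2 (0.23 log units; within the scatter) was that small, a further change of chain length is not expected to move the number beyond the scatter either, with at most a slight lowering.

Compound 3 is therefore expected to give 800 nM in this assay, with a range from 350 nM to 1800 nM, an expected step of a 1.5-fold lower number from compound 2 to compound 3 (0.16 log units; within the scatter).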

Compound 3, half-maximal inhibitory concentration: 300 nM
For compound 3 the middle estimate is 2.7-fold (0.43 log units) above the measured one, outside the stated range (below it).
By their numbers in this assay, from the lowest: compound 3; then compounds 1 and 2 (each within the scatter of the next).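

Within the data shown here, at this position on a saturated chain carbon, propyl in place of hydrogen moves the number in this assay by a modest but real amount: the change gives a 3.9-fold lower number from compound 2 to compound 3 (0.59 log units; beyond the scatter) and is the first step in this set to pass beyond the scatter. Pentyl in place of hept-1-en-1-yl, on a saturated chain carbon, nine bonds along the chain from a saturated ring carbon, gives a 2.3-fold lower number from compound 1 to compound 3 (0.36 log units; beyond the scatter) and so places compound 3 lowest of the three, which here means the strongest inhibition. Compound 1 goes against any simple rule that more chain means a lower number, as its hept-1-en-1-yl group is larger than the pentyl group of compound 3, yet compound 3 gives the lower number.

Still open, from the compounds shown here alone, is whether a longer saturated chain would lower the number further or raise it again, and whether a carboxylic acid in place of the ester would preserve the value of compound 3. Nothing available explains why this change lowers the number.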